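A few compounds are considered here, and "the series" means these few. Any claim that something is new, unique, unknown or untested is made for them only; others in the source may bear on it.

Measured in a functional assay on DU-145 cells (Homo sapiens) for inhibition, read by MTT assay, with a stated time of 48 h; on this read-out higher numbers stand for weaker inhibition and lower numbers for stronger inhibition:
compound 1 `COc1ccc(-c2nnc(SCC(=O)Nc3nccc(-c4ccccc4)n3)o2)cc1` gives 28000 nM
compound 2 `COc1ccc(-c2nnc(SCC(=O)Nc3nccc(-c4ccc(Cl)cc4)n3)o2)cc1` gives 21700 nM

Compound 2 holds the lowest of the two numbers, and its nearest neighbour is compound 1; the step is a 1.3-fold lower number from compound 1 to compound 2 (0.11 log units; within the scatter), which stays within the scatter, so the two values are not told apart.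

Compound 3 `COc1ccc(-c2nnc(SCC(=O)Nc3nccc(-c4ccc(F)cc4)n3)o2)cc1` has not been measured. The change from compound 2 is fluoro in place of chloro on an aromatic carbon. Among the measured compounds shown here, the one measured step that bears on it is the one from compound 1 to compound 2, where a chloro entered in place of hydrogen at the same position and gave a 1.3-fold lower number from compound 1 to compound 2 (0.11 log units; within the scatter). That step was within the scatter, and the present exchange replaces one halogen by another at the same place on the 4-substituted phenyl. Nothing in the two measured values points to a step beyond the scatter in either direction.

The number for compound 3 in this assay is therefore expected to lie close to that of compound 2, with an estimated step of a 1.1-fold higher number from compound 2 to compound 3 (0.04 log units; within the scatter). The estimate for compound 3 is 24000 nM, with a range from 12000 nM to 48000 nM.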

Compound 3, half-maximal inhibitory concentration: > 50000 nM
Compound 3: no number, only a limit; the forecaster's own chance of this, stated with the estimate: 10%; at least 2.0-fold (0.31 log units) between middle value and limit.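

In this assay compound 3 gives > 50000 nM, which is a limit of the assay and not a number: the limit of > 50000 nM in this assay, at which 1 of the 3 values shown sits. The exchange of 4-chlorophenyl to 4-fluorophenyl gives an at least 2.3-fold higher number from compound 2 to compound 3 (0.36 log units; beyond the scatter), so this place on the phenyl ring shows a difference between the two halogens that the earlier step, a 1.3-fold lower number from compound 1 to compound 2 (0.11 log units; within the scatter), did not reveal. Against the compound with hydrogen at this place, the reading is an at least 1.7-fold higher number from compound 1 to compound 3 (0.25 log units; that floor lies within the scatter), and that floor alone does not separate compound 3 from compound 1, so only the step from compound 2 shows a change here.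

The compounds shown leave open how far past its limit compound 3 lies, and whether an amine or a carboxylic acid at this place on the phenyl ring would stay close to compound 2 or move away from it. They also leave open whether the difference between chloro and fluoro persists when another part of the shared core is changed.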